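Extending the Sulfur Chain with a Hydroxyl Group

A few compounds are considered here, and "the series" means these few. Any claim that something is new, unique, unknown or untested is made for them only; others in the source may bear on it.

Within the data shown here, compound 2 `CSc1nc2cc(S(=O)(=O)NCc3ccc(F)cc3)ccc2n1Cc1ccccc1` stands at the higher of the two numbers so far in an assay on isolated protein for inhibition of Gonadotropin-releasing hormone receptor (Rattus norvegicus) (on this read-out higher numbers stand for weaker inhibition and lower numbers for stronger inhibition), where compound 2 gives 210 nM. Its nearest neighbour is compound 1 `CCSc1nc2cc(S(=O)(=O)NCc3ccc(F)cc3)ccc2n1Cc1ccccc1`, which in this assay gives 200 nM; the step of a 1.1-fold higher number from compound 1 to compound 2 (0.02 log units; within the scatter) lies within the scatter, so the two values cannot be ordered. Compound 3 `O=S(=O)(NCc1ccc(F)cc1)c1ccc2c(c1)nc(SCCO)n2Cc1ccccc1` carries hydroxymethyl in place of hydrogen on a saturated chain carbon bound to a sulfur. Among the measured compounds shown here, the only measured step touching this position is the one from compound 1 to compound 2, which shows that a change in the chain on the sulfur left the number unchanged. For the measured compounds named here, on that basis a step of the same kind is expected for compound 3, none beyond the scatter, although the entering group brings a hydrogen-bond donor and acceptor that no measured compound has, so the range is kept wide. The estimate for compound 3 in this assay is 250 nM, between 100 nM and 700 nM, which means an expected step of a 1.2-fold higher number from compound 2 to compound 3 (0.08 log units; within the scatter).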

Compound 3, half-maximal inhibitory concentration: 600 nM
Compound 3: the middle estimate sits 2.4-fold (0.38 log units) below what was measured; the measured number falls inside the stated range.
By their numbers in this assay, from the lowest: compounds 1 and 2 (each within the scatter of the next); then compound 3.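

In this assay, the chain on the sulfur proves sensitive to at least one change: hydroxymethyl in place of hydrogen gives a 2.9-fold higher number from compound 2 to compound 3 (0.46 log units; beyond the scatter), beyond the scatter and modest in size. Hydroxy in place of hydrogen on the chain of compound 1 gives a 3.0-fold higher number from compound 1 to compound 3 (0.48 log units; beyond the scatter), also beyond the scatter and modest, so a change at this position can weaken inhibition, which the step between the two earlier compounds did not show. No evidence at hand accounts for this weakening.

As far as these compounds go, whether a methoxy group, an amine or a carboxylic acid in place of the hydroxy would give a step of similar size remains open. So does whether a longer chain carrying the hydroxy would follow compound 3 or return towards compound 1.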